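The compounds below may be only part of what the source reports. "The series", "measured", "known", "first", "only" and "open" are said of these compounds alone.

Measured so far in a functional assay on HCC827 cells (Homo sapiens) for inhibition, read by MTT assay, with a stated time of 48 h, tested at 10 uM; a higher number here means more inhibition at the concentration tested (going by the name of the read-out), a lower number less inhibition:
compound 1, `Cc1ccc(Nc2cc(NC(=O)Nc3c(Cl)cccc3Cl)ncn2)cc1F` — 85.3%
compound 2, `COc1cc(NC(=O)Nc2cc(Nc3cccc(C(C)(C)C)c3)ncn2)cc(OC)c1` — 48.7%
compound 3, `COc1ccc(C(F)(F)F)cc1Nc1cc(NC(=O)Nc2c(Cl)cccc2Cl)ncn1` — 68.7%

Compound 2 gives the lowest of the three numbers in this assay: compound 3 stands higher by a margin beyond the scatter, and compound 1 higher still, also beyond the scatter. The unmeasured compound 4, `COc1cc(NC(=O)Nc2cc(Nc3cc(I)ccc3OC)ncn2)cc(OC)c1`, keeps the urea part of compound 2 and changes the aryl group on the amine: 5-iodo-2-methoxyphenyl in place of 3-(tert-butyl)phenyl on a nitrogen on an aromatic ring. For the measured compounds named here, no step between measured compounds isolates this change; compound 3 carries a methoxy-bearing aryl on the same nitrogen, but with a different urea part, so it offers only loose guidance. A modest rise is expected, near the edge of the scatter, as the expected step of a number 9.3 percentage points higher from compound 2 to compound 4 (within the scatter) shows. Compound 4 is estimated at 58%, with a range of 36% to 78%.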

Compound 4, a percentage reported as inhibition, at one concentration (the size of the read-out at that concentration, not a potency): 71%
The estimate for compound 4 lay 13 percentage points below the measured number; low and high end bracket the measured number.
By their numbers in this assay, from the lowest: compound 2; then compounds 3 and 4 (each within the scatter of the next); then compound 1.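

With the urea part of compound 2 held fixed, 5-iodo-2-methoxyphenyl in place of 3-(tert-butyl)phenyl on the nitrogen gives a number 22.3 percentage points higher from compound 2 to compound 4 (beyond the scatter) in this assay. For the compounds shown here, this is the first single-place reading, and it shows that the aryl group on this nitrogen alone can move the read-out beyond the scatter. Nothing at hand gives a reason for the step.

As far as these compounds go, whether the methoxy or the iodine carries the step remains open, as does the effect of a chlorine or an amine in place of the iodine. Also open, from the compounds shown here alone, is whether the change holds with the urea part of compound 1.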